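Notes on replacing the 4-methoxyphenyl on compound 1

A few compounds are considered here, and "the series" means these few. Any claim that something is new, unique, unknown or untested is made for them only; others in the source may bear on it.

Compound 1 `COc1ccc(C(=O)Nc2nn(-c3ccccc3)c(=O)c3ccccc23)cc1` is the reference point of this series. Among the measured compounds shown here, in an assay on CHO cells for displacement of a labelled ligand from adenosine receptor A1 (Homo sapiens), tested at 10 uM (on this read-out lower numbers stand for less inhibition and higher numbers for more inhibition at the one concentration tested (going by the name of the read-out)), compound 1 gives 0%, the lowest of the two numbers measured so far; its nearest neighbour is compound 2 `COc1ccc(NC(=O)Nc2nn(-c3ccccc3)c(=O)c3ccccc23)cc1`, which in this assay gives 4%. For the measured compounds named here, the one measured step, a number 4 percentage points higher from compound 1 to compound 2 (within the scatter), puts (4-methoxyphenyl)amino in place of 4-methoxyphenyl on a carbonyl carbon and stays within the scatter.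

Compound 3 `COc1ccccc1CNC(=O)Nc1nn(-c2ccccc2)c(=O)c2ccccc12` has not yet been measured. It differs from compound 1 by (2-methoxybenzyl)amino in place of 4-methoxyphenyl on a carbonyl carbon. The step from compound 1 to compound 2 is the only measured one that bears on it, since both changes replace the 4-methoxyphenyl on the carbonyl carbon, and that step stayed within the scatter. Neither measured compound shows inhibition beyond the scatter, so no step beyond the scatter is expected in this assay here either. Compound 3 is therefore expected to give about 3%, with a range from -6% to 14%. The step of a number 3 percentage points higher from compound 1 to compound 3 (within the scatter) is estimated to lie within the scatter, because a number 4 percentage points higher from compound 1 to compound 2 (within the scatter) did so for the related change.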

Compound 3, a percentage reported as inhibition, at one concentration (the size of the read-out at that concentration, not a potency): 28%
Compound 3: middle estimate off by 25 percentage points, on the low side; measured number above the stated range.
By their numbers in this assay, from the lowest: compounds 1 and 2 (each within the scatter of the next); then compound 3.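

The group on the carbonyl carbon can change the reading in this assay: the earlier pair stayed within the scatter, whereas the change to (2-methoxybenzyl)amino gives a number 28 percentage points higher from compound 1 to compound 3 (beyond the scatter), so this position is not indifferent to what is placed there. The urea-type link alone does not account for the difference, as compound 2 and compound 3 both carry an amino group on that carbonyl carbon, and replacing 4-methoxyphenyl with 2-methoxybenzyl on the amide-type nitrogen gives a number 24 percentage points higher from compound 2 to compound 3 (beyond the scatter). Nothing available on this series offers an explanation for the higher reading of compound 3.

The step from compound 2 to compound 3 changes the aryl group to a benzyl group and moves the methoxy in one go, so the compounds shown do not tell which of these two differences carries the step. An unsubstituted benzyl, 4-methoxybenzyl or 2-methoxyphenyl group would separate the two, and a longer chain such as 2-phenylethyl would show whether the reading in this assay continues to climb as the aromatic ring moves further from the amide-type nitrogen.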